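Urea to amide on the shared core: expected loss of activity

This account rests on a few compounds, and the source may have more. Where it says the series, first, only, none or still open, it means among the compounds named here.

Compound 2 `COc1cc(Cl)cc(-c2nn(-c3cccc(NC(=O)Nc4ccc(Cl)c(Cl)c4)c3)cc2-c2ccncc2)c1` holds the lowest number of the two compounds measured in a functional assay on MDA-MB-435 cells (Homo sapiens) for inhibition, read by sulforhodamine B assay, with a stated time of 48 h, tested at 10 uM (on this read-out higher numbers stand for a weaker effect at the one concentration tested and lower numbers for a stronger effect), where compound 2 gives 0.46%. Within the data shown here, compound 1 `COc1cc(Cl)cc(-c2nn(-c3cccc(NC(=O)c4ccc(Cl)c(Cl)c4)c3)cc2-c2ccncc2)c1` shares the core and in this assay compound 1 gives 80.8%; the step of a number 80.3 percentage points lower from compound 1 to compound 2 (beyond the scatter) is the only measured step and it bears directly on the change considered here. Compound 3 `COc1cc(Cl)cc(-c2nn(-c3cccc(NC(=O)c4cccc(C(F)(F)F)c4)c3)cc2-c2ccncc2)c1` has not been measured. It differs from compound 2 in the way (3-(trifluoromethyl)phenyl in place of (3,4-dichlorophenyl)amino on a carbonyl carbon), which undoes the kind of change seen between compound 1 and compound 2 while also carrying a different aryl group. Because a number 80.3 percentage points lower from compound 1 to compound 2 (beyond the scatter) was large, the reverse direction is expected to bring a large rise in the read-out for compound 3, though its new aryl group adds uncertainty. For compound 3 the step of a number 69.5 percentage points higher from compound 2 to compound 3 (beyond the scatter) is expected, giving an estimated value of 70% with a range from 30% to 98%.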

Compound 3, a percentage reported as activity, at one concentration (the size of the read-out at that concentration, not a potency): 65.6%
For compound 3 the middle estimate is 4.4 percentage points above the measured one; the measured number falls inside the stated range.
By their numbers in this assay, from the lowest: compound 2; then compound 3; then compound 1.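

In this assay, the step of a number 65.1 percentage points higher from compound 2 to compound 3 (beyond the scatter) shows that the weak effect seen with the amide compound 1 is not confined to the 3,4-dichlorophenyl group: a second amide, carrying 3-(trifluoromethyl)phenyl, also stands far from the urea compound 2. Within the amides, the step of a number 15.2 percentage points lower from compound 1 to compound 3 (beyond the scatter) shows that the aryl group on the carbonyl carbon does move the read-out, though by much less than the change from amide to urea. Nothing available gives a reason for either step.

Going by these compounds, the step from compound 2 to compound 3 changes the aryl group and the urea together, so it remains open how a urea carrying 3-(trifluoromethyl)phenyl would behave. On these data alone, it is also open whether a carbamate or a sulfonamide in this place would give a read-out closer to the urea or to the amides.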